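Swapping the Aryl Group on a Shared Core

A few compounds are considered here, and "the series" means these few. Any claim that something is new, unique, unknown or untested is made for them only; others in the source may bear on it.

Compound 1 `COc1cccc(NC2=CC(=O)c3c(nc4n3[C@H]3OC[C@@H](O)[C@H]3OC4)C2=O)c1` carries 3-methoxyphenyl on an amine nitrogen whose other neighbours are a double-bonded ring carbon. In a functional assay on HeLa cells (Homo sapiens) for inhibition, read by sulforhodamine B assay (on this read-out higher numbers stand for weaker inhibition and lower numbers for stronger inhibition), compound 1 gives > 8000 nM, which is a limit of the assay rather than a number. Compound 1 thus sits at the limit of > 8000 nM in this assay, at which 1 of the 2 values shown sits. Compound 2 `O=C1C=C(NC2CCCC2)C(=O)c2c1nc1n2[C@H]2OC[C@@H](O)[C@H]2OC1` shares the same core with a different group on that nitrogen. In this assay compound 2 gives > 16000 nM, also a limit. Compound 2 sits at the limit of > 16000 nM in this assay, at which 1 of the 2 values shown sits. The two limits allow no order between compound 1 and compound 2. Compound 3 `CCc1ccc(NC2=CC(=O)c3c(nc4n3[C@H]3OC[C@@H](O)[C@H]3OC4)C2=O)cc1` is the unmeasured partner of compound 1: 4-ethylphenyl in place of 3-methoxyphenyl on an amine nitrogen. No step between measured compounds is known, so the account rests only on the two limits shown. The estimated step from compound 1 to compound 3 is a step that the limit leaves unreadable from compound 1 to compound 3, expected to stay within the scatter rather than beyond it. Compound 3 is therefore expected to give 12000 nM, within a range from 4000 nM to 40000 nM, and most likely to return only a limit again.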

Compound 3, half-maximal inhibitory concentration: 6510 nM
For compound 3 the middle estimate is 1.8-fold (0.27 log units) above the measured one, within the range that was stated.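

Within the data shown here, with 4-ethylphenyl on the amine nitrogen, compound 3 gives 6510 nM in this assay, the first actual number on this shared core rather than a limit. Replacing 3-methoxyphenyl with 4-ethylphenyl at this position gives an at least 1.2-fold lower number from compound 1 to compound 3 (0.08 log units; that floor lies within the scatter), so the compounds shown now include a measurable inhibition value for an aryl group on this nitrogen. Compound 1 still stands only at a limit, so the full size of the step cannot be read: the limit of > 8000 nM in this assay, at which 1 of the 3 values shown sits.

The compounds shown leave open whether the ethyl group, the methoxy group or the place of each on the ring governs the read-out, which 3-ethylphenyl and 4-methoxyphenyl on the same nitrogen would separate. Going by these compounds, how a longer chain, as in 4-butylphenyl, or an amine, as in 4-aminophenyl, would read in this assay also remains open.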